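Removing a Chloro Group in Two Cyclopropane Diastereomers

The compounds below may be only part of what the source reports. "The series", "measured", "known", "first", "only" and "open" are said of these compounds alone.

Measured so far in a functional assay on K562 cells (Homo sapiens) for cytotoxicity, read by MTT assay, with a stated time of 48 h; a lower number here means a stronger inhibitor, a higher number a weaker inhibitor:
- compound 1, `CCOC(=O)[C@]1(C(=O)Nc2ccccc2)C[C@H]1c1cc(OC)c(OC)c(OC)c1`, gives > 100000 nM
- compound 2, `CCOC(=O)[C@]1(C(=O)Nc2ccccc2Cl)C[C@H]1c1cc(OC)c(OC)c(OC)c1`, gives 20700 nM
- compound 3, `CCOC(=O)[C@@]1(C(=O)Nc2ccccc2Cl)C[C@H]1c1cc(OC)c(OC)c(OC)c1`, gives > 100000 nM

Of these three, only compound 2 returns a number in this assay. The value of compound 1 is a limit of the assay, not a number. The value of compound 3 is likewise a limit. Compound 2 and compound 1 share the same core and differ by hydrogen in place of chloro on an aromatic carbon; this change gives an at least 4.8-fold higher number from compound 2 to compound 1 (0.68 log units; beyond the scatter). Compound 2 and compound 3 differ in their cores: the two compounds have the same atoms and bonds and differ only in configuration as drawn: 1 of 2 stereo elements differ; a stereocentre at a saturated ring carbon is drawn R in compound 2 and S in compound 3. That step is an at least 4.8-fold higher number from compound 2 to compound 3 (0.68 log units; beyond the scatter). Both steps are open-ended at the top because of the limit of > 100000 nM in this assay, at which 2 of the 3 values shown sit. That the second step rests on configuration alone follows from the fact that compounds 2 and 3 differ only in the configuration as drawn.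

Compound 4, `CCOC(=O)[C@@]1(C(=O)Nc2ccccc2)C[C@H]1c1cc(OC)c(OC)c(OC)c1`, is not yet measured. It differs from compound 3 by hydrogen in place of chloro on an aromatic carbon, the same change as that from compound 2 to compound 1, now made on the core of compound 3. From compound 3 to compound 4 the step is estimated to be a step that the limit leaves unreadable from compound 3 to compound 4, set beside the earlier one. This expectation rests on the limit at which compound 3 already sits. It also rests on the weakening seen in an at least 4.8-fold higher number from compound 2 to compound 1 (0.68 log units; beyond the scatter). Compound 4 is therefore expected to give about 200000 nM, between 100000 nM and 1000000 nM, most likely reported only as a limit in this assay.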

Compound 4, half-maximal inhibitory concentration: > 100000 nM
Compound 4 was reported as a limit (the forecaster's own chance of this, stated with the estimate: 90%); the middle value is on the limit's open side.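

In this assay compound 4 gives > 100000 nM, which is a limit of the assay and not a number. No size can be read for the steps from compound 3 to compound 4 or from compound 1 to compound 4, because both ends of each step rest on: the limit of > 100000 nM in this assay, at which 3 of the 4 values shown sit.

The compounds shown leave open whether removing the chloro group changes anything on the core of compound 3, and whether configuration matters without that group.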